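The source may report more compounds than this note shows. Statements on the series, on what has been measured and on what is new or still open speak of the compounds shown alone.

Among the measured compounds shown here, in an in vitro assay on Sf21 cells for inhibition of high affinity 3',5'-cyclic-AMP phosphodiesterase 7A (Homo sapiens) (a lower number here means a stronger inhibitor, a higher number a weaker inhibitor), compound 3, `CNc1nc(NC2(C#N)CCCCC2)nc(-n2ccnc2)n1`, gives 1050 nM, the only value in this set that is a number rather than a limit. Compound 1, `CNc1nc(NC2(C#N)CCCCC2)nc(-n2cccn2)n1`, gives > 5000 nM, which is a limit of the assay. Compound 2, `CNc1nc(NC2(C#N)CCCCC2)nc(-n2cncn2)n1`, gives > 5000 nM, likewise a limit. Compound 4, `CNc1nc(NC2(C#N)CCCCC2)nc(OC)n1`, has not yet been measured; it differs from compound 3 in one place: methoxy in place of 1H-imidazol-1-yl on an aromatic carbon. For the measured compounds named here, of the measured steps, an at least 4.7-fold lower number from compound 1 to compound 3 (0.67 log units; beyond the scatter) and an at least 4.7-fold lower number from compound 2 to compound 3 (0.67 log units; beyond the scatter) both concern the exchange of one five-membered ring for another at the same carbon, and in each the 1H-imidazol-1-yl compound is the only one with a readable number; a step that the two limits leave unreadable from compound 1 to compound 2 cannot be sized, because both values sit at the limit of > 5000 nM in this assay, at which 2 of the 3 values shown sit. Going by the values given here, none of these steps removes the ring altogether, so the step to methoxy has no direct precedent among the measured compounds. Compound 1 and compound 2 gave only limits while compound 3 alone gave a number, and on that basis the step in this assay from compound 3 to compound 4 is expected to be toward a higher number, roughly a 2.9-fold higher number from compound 3 to compound 4 (0.46 log units; beyond the scatter). Compound 4 is therefore estimated at 3000 nM, with a range from 800 nM to 12000 nM, and a fair chance that only a limit is reported.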

Compound 4, half-maximal inhibitory concentration: 521 nM
The estimate for compound 4 lay 5.8-fold (0.76 log units) above the measured number; the whole stated range lies above it.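

In this assay, the result shows that a five-membered aromatic ring is not needed at this carbon, between two ring nitrogen atoms: a 2.0-fold lower number from compound 3 to compound 4 (0.30 log units; within the scatter), so methoxy, with no ring and fewer heavy atoms, cannot be told apart from 1H-imidazol-1-yl. Methoxy also stands clearly apart from the other two rings, with an at least 9.5-fold lower number from compound 2 to compound 4 (0.98 log units; beyond the scatter) and an at least 9.5-fold lower number from compound 1 to compound 4 (0.98 log units; beyond the scatter), so the earlier picture of 1H-imidazol-1-yl as the only group here giving a readable number no longer holds. These two steps give only a lower bound on size, not a size, because compound 1 and compound 2 each rest on a limit: the limit of > 5000 nM in this assay, at which 2 of the 4 values shown sit.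

The compounds shown leave open whether other small groups at this carbon, such as ethoxy, a hydroxyl group or a dimethylamino group, would match methoxy or fall to the limit. They also do not say what separates methoxy and 1H-imidazol-1-yl from 1H-pyrazol-1-yl and 1H-1,2,4-triazol-1-yl, as the four groups share no single feature that these few values could isolate.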